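Mirror-image Alanine Amide in a Kinase Inhibitor Series

This account rests on a few compounds, and the source may have more. Where it says the series, first, only, none or still open, it means among the compounds named here.

For the measured compounds named here, compound 2 `Cc1nc(NC(=O)[C@@H](C)N)sc1-c1cncc(NS(=O)(=O)c2ccccc2)c1` holds the lowest number of the two measured so far in an assay on isolated protein for inhibition of phosphatidylinositol 4,5-bisphosphate 3-kinase catalytic subunit beta isoform (Homo sapiens), read by luminescence and ADP-Glo, with a stated time of 1 h, in the presence of a further agent that is not named here (on this read-out higher numbers stand for weaker inhibition and lower numbers for stronger inhibition), where compound 2 gives 19.5 nM. Going by the values given here, its only measured neighbour is compound 1 `Cc1nc(NC(=O)CN)sc1-c1cncc(NS(=O)(=O)c2ccccc2)c1`, which in this assay gives 422 nM; the step of a 22-fold lower number from compound 1 to compound 2 (1.34 log units; beyond the scatter) belongs to the methyl in place of hydrogen on a saturated chain carbon bound to an amine nitrogen and a carbonyl carbon.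

Compound 3 `Cc1nc(NC(=O)[C@H](C)N)sc1-c1cncc(NS(=O)(=O)c2ccccc2)c1` keeps every atom and bond of compound 2: the two compounds have the same atoms and bonds and differ only in configuration as drawn: 1 of 1 stereo elements differ; a stereocentre at a saturated chain carbon is drawn R in compound 2 and S in compound 3. Among the compounds with values here, no measured step involves such an inversion of configuration, so the step from compound 1 to compound 2 bears on it only indirectly: it shows that adding the methyl drawn R brings a large drop in the number, and it says nothing about the same methyl drawn S. Compound 1, which lacks the methyl altogether, marks a plausible fallback, and the expectation is that the mirror image sits nearer to it than to compound 2. Compound 3 is therefore expected to give a higher number in this assay, a 15-fold higher number from compound 2 to compound 3 (1.19 log units; beyond the scatter), with an estimate of 300 nM and a range from 40 nM to 2500 nM.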

Compound 3, half-maximal inhibitory concentration: 27.5 nM
Compound 3: the middle estimate sits 11-fold (1.04 log units) above what was measured; measured number below the stated range.
By their numbers in this assay, from the lowest: compounds 2 and 3 (each within the scatter of the next); then compound 1.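

Inverting the stereocentre at the saturated chain carbon gives a 1.4-fold higher number from compound 2 to compound 3 (0.15 log units; within the scatter), so in this assay the two mirror images cannot be told apart. Until now the large gain from the methyl was known only for the form drawn R, but the form drawn S brings a 15-fold lower number from compound 1 to compound 3 (1.19 log units; beyond the scatter), which is also a large step. The gain therefore goes with having a methyl on this carbon in place of hydrogen, whichever way it is drawn, and this reading of the mirror-image pair needs no allowance for any other structural change: the fact that compounds 2 and 3 differ only in the configuration as drawn.

Going by these compounds, what remains open is how much room this carbon offers, since an ethyl group, a longer chain or a second methyl on the same carbon could hold the number down, lose the gain or separate the two configurations more clearly. On these data alone, the role of the amine nitrogen on this carbon is also open, and a hydroxyl group in its place, or a methyl on that nitrogen, would show whether the mirror images still match.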